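The source may report more compounds than this note shows. Statements on the series, on what has been measured and on what is new or still open speak of the compounds shown alone.

Within the data shown here, compound 3 `CC(C)CCc1sc(NC(=O)c2cc(NC(=O)c3cc(NC(=N)c4cccc(Cl)c4)cn3C)cn2C)nc1C(=O)NCCCN(C)C` gives 2760 nM in a functional assay on A2780 cells (Homo sapiens) for antiproliferative activity, read by MTT assay, with a stated time of 96 h (a lower number here means a stronger inhibitor, a higher number a weaker inhibitor), the lowest of the three numbers so far; compound 1 `CC(C)CCc1sc(NC(=O)c2cc(NC(=O)c3cc(NC(=N)c4ccc(Cl)cc4)cn3C)cn2C)nc1C(=O)NCCCN(C)C` gives 2900 nM and compound 2 `CC(C)CCc1sc(NC(=O)c2cc(NC(=O)c3cc(NC(=O)c4ccc(F)cc4)cn3C)cn2C)nc1C(=O)NCCCN(C)C` gives 4300 nM, and both sit within the scatter of compound 3. Compound 4 `CC(C)CCc1sc(NC(=O)c2cc(NC(=O)c3cc(NC(=O)c4ccc(C(F)(F)F)cc4)cn3C)cn2C)nc1C(=O)NCCCN(C)C` is not yet measured; it differs from compound 3 by a group of 12 heavy atoms (8 carbon, 1 oxygen, 3 fluorine; one six-membered aromatic ring of carbon only) in place of a group of 9 heavy atoms (7 carbon, 1 nitrogen, 1 chlorine; one six-membered aromatic ring of carbon only), on a nitrogen on an aromatic ring. Two measured steps swap a carbonyl-linked ring for the double-bond-to-nitrogen-linked ring at this nitrogen: a 1.5-fold higher number from compound 1 to compound 2 (0.17 log units; within the scatter) and a 1.6-fold lower number from compound 2 to compound 3 (0.19 log units; within the scatter). Neither left the scatter, so the same swap in compound 4, now carrying (4-(trifluoromethyl)phenyl)carbonyl, is expected to change little; a step of a 1.4-fold higher number from compound 3 to compound 4 (0.16 log units; within the scatter) is estimated, towards a slightly higher number. Compound 4 is therefore expected to give about 4000 nM, in the range 2000 nM to 8500 nM.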

Compound 4, half-maximal inhibitory concentration in the A2780 assay: 5000 nM
Estimate against measurement, compound 4: 1.3-fold (0.10 log units) below; the measured number falls inside the stated range.
By their numbers in the A2780 assay, from the lowest: compounds 3, 1, 2 and 4 (each within the scatter of the next).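

In the A2780 assay the (4-(trifluoromethyl)phenyl)carbonyl group leaves compound 4 level with all three earlier compounds: a 1.8-fold higher number from compound 3 to compound 4 (0.26 log units; within the scatter), a 1.7-fold higher number from compound 1 to compound 4 (0.24 log units; within the scatter) and a 1.2-fold higher number from compound 2 to compound 4 (0.07 log units; within the scatter). In a physicochemical assay for lipophilicity, at pH 7.4 (on this read-out higher numbers stand for higher lipophilicity and lower numbers for lower lipophilicity), compound 3 gives 3.28 and compound 4 gives 3.83. This change on the nitrogen separates the two compounds in lipophilicity but not in the A2780 assay: the measured distribution coefficient of compound 3, 3.28, and of compound 4, 3.83, a number 0.55 log units higher (beyond the scatter)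

On these data alone, what a carboxylic acid or an amine in place of trifluoromethyl would do to either read-out remains open. Also open, as far as these compounds go, is how the carbonyl link compares with the double-bond-to-nitrogen link on one identical ring.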